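Trading 2,4-dichlorobenzyl for 4-fluorobenzyl

The source may hold more compounds than are shown below. What is called first, only, known or untested is meant among the compounds shown, and "the series" means these compounds.

Among the measured compounds shown here, in a functional assay on HeLa cells (Homo sapiens) for cytotoxicity, read by MTT assay, with a stated time of 48 h (a higher number here means a weaker inhibitor, a lower number a stronger inhibitor), compound 2 (`O=c1ccoc2cc(OCc3cn(Cc4ccc(Cl)cc4Cl)nn3)ccc12`) gives 80600 nM as its value, the higher of the two numbers so far and so the weaker inhibitor of the pair. For the measured compounds named here, its only neighbour, compound 1 (`O=c1ccoc2cc(OCc3cn(Cc4ccc(Cl)cc4)nn3)ccc12`), gives 37600 nM as its value. Compound 3 (`O=c1ccoc2cc(OCc3cn(Cc4ccc(F)cc4)nn3)ccc12`) has not yet been measured. Its difference from compound 2 is 4-fluorophenyl in place of 2,4-dichlorophenyl on a saturated chain carbon bound to an aromatic nitrogen and amounts to 4-fluorophenyl in place of 2,4-dichlorophenyl on a saturated chain carbon bound to an aromatic nitrogen. Going by the values given here, the one measured step that bears on this is a 2.1-fold higher number from compound 1 to compound 2 (0.33 log units; beyond the scatter) and it is modest, a chloro in place of hydrogen on an aromatic carbon. Among the compounds with values here, compound 3 carries no chloro, while no step involving fluoro has been measured. A modest move toward a lower number is therefore expected, and the expected step is a 2.0-fold lower number from compound 2 to compound 3 (0.30 log units; within the scatter) in this assay as estimated here. Compound 3 is estimated at 40000 nM (range 18000 nM to 85000 nM).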

Compound 3, half-maximal inhibitory concentration: 12000 nM
For compound 3 the middle estimate is 3.3-fold (0.52 log units) above the measured one; the whole stated range lies above it.
By their numbers in this assay, from the lowest: compound 3; then compound 1; then compound 2.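

In this assay the full exchange gives a 6.7-fold lower number from compound 2 to compound 3 (0.83 log units; beyond the scatter) and fluoro in place of chloro alone gives a 3.1-fold lower number from compound 1 to compound 3 (0.50 log units; beyond the scatter) on the same scale. Among the compounds shown here, until now the only measured change on this aromatic ring was an added chloro, which raised the number; these steps show that the identity of the halogen also counts, not only whether a chloro is added. Both steps run toward a lower number, so among the three compounds the 4-fluorobenzyl group gives the strongest inhibitor, with its steps to both others beyond the scatter.

Still open, from the compounds shown here alone, is how a plain phenyl with no halogen, or a 4-methoxyphenyl, would read on this saturated chain carbon. Going by these compounds, it is also open whether a 2,4-difluorophenyl would follow the same direction. The data offer no measurement that explains these shifts.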